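Methoxy for chloro: expected acid dissociation of compound 4

This account rests on a few compounds, and the source may have more. Where it says the series, first, only, none or still open, it means among the compounds named here.

compound 1 `CN(Cc1ccc(N(C)C)cc1)Cc1cccc(CNc2ccnc3cc(Cl)ccc23)c1` gives 9.67
compound 2 `CN(Cc1ccc(Cl)cc1)Cc1ccc(CNc2ccnc3cc(Cl)ccc23)cc1` gives 9.74
compound 3 `CN(Cc1ccc(Cl)cc1)Cc1cccc(CNc2ccnc3cc(Cl)ccc23)c1` gives 9.89

These three values come from a physicochemical assay for acid dissociation, and lie within the usual scatter of one another, so compound 2 sits level with both neighbours. Going from compound 2 to compound 4 `COc1ccc(CN(C)Cc2ccc(CNc3ccnc4cc(Cl)ccc34)cc2)cc1` puts methoxy in place of chloro on an aromatic carbon. Among the compounds with values here, no measured step involves methoxy. The closest one is chloro in place of dimethylamino on an aromatic carbon. With a number 0.22 log units higher from compound 1 to compound 3 (within the scatter) as that only guide, no step beyond the scatter is expected in this assay here. The expected step is a number 0.01 log units higher from compound 2 to compound 4 (within the scatter) and would stay inside the scatter. Compound 4 is estimated at 9.75 (expected range from 9.45 to 10.05).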

Compound 4, acid dissociation constant: 9.7
The estimate for compound 4 lay 0.05 log units above the measured number; the measured number falls inside the stated range.
By their numbers in this assay, from the lowest: compounds 1, 4, 2 and 3 (each within the scatter of the next).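

In this assay the change from 4-chlorophenyl to 4-methoxyphenyl gives a number 0.04 log units lower from compound 2 to compound 4 (within the scatter) and so provides a direct reading for methoxy on this aromatic carbon, para to a large group. Here, replacing chloro with methoxy adds one hydrogen-bond acceptor and one heavy atom, yet the two numbers stay level. No measurement shown here explains this result.

On these data alone, whether a carboxylic acid or a primary amine in this place would also stay within the scatter remains open. So does whether methoxy would leave the number level on the core of compound 3.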